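The source may report more compounds than this note shows. Statements on the series, on what has been measured and on what is new or still open speak of the compounds shown alone.

Measured compounds:
compound 1 `COc1cc(/C=C/C(=O)c2cccc(N=[N+]=[N-])c2)ccc1O`, 7110 nM
compound 2 `COc1cc(/C=C/C(=O)c2cccc(-n3cc(-c4ccc(F)cc4)nn3)c2)ccc1O`, 6450 nM
compound 3 `COc1cc(/C=C/C(=O)c2cccc(-n3cc(-c4ccc(C)cc4)nn3)c2)ccc1O`, 15400 nM

In a functional assay on RAW264.7 cells (Mus musculus) for inhibition, with a stated time of 4 days (a lower number here means a stronger inhibitor, a higher number a weaker inhibitor), compound 1 gives 7110 nM, compound 2 gives 6450 nM, and compound 3 gives 15400 nM. Compound 3 carries the highest number of the three: the step of a 2.4-fold higher number from compound 2 to compound 3 (0.38 log units; beyond the scatter) is modest but beyond the scatter, and its gap to compound 1 is likewise beyond the scatter.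

Compound 4 `COc1cc(/C=C/C(=O)c2cccc(-n3cc(-c4ccccc4C(F)(F)F)nn3)c2)ccc1O` differs from compound 3 in one place: 2-(trifluoromethyl)phenyl in place of 4-methylphenyl on an aromatic carbon. Among the compounds with values here, the only measured step that bears on this change is a 2.4-fold higher number from compound 2 to compound 3 (0.38 log units; beyond the scatter), which shows that swapping a substituent on this phenyl ring shifted the number by a modest amount. Within the data shown here, compound 4 brings fluorine back, now within a trifluoromethyl group at a different position on the ring; no measured pair covers that exact swap, so the direction is uncertain. A modest lowering toward compound 2 is expected. Compound 4 is estimated at 9000 nM, within 3000 nM to 30000 nM. The expected step of a 1.7-fold lower number from compound 3 to compound 4 (0.23 log units; within the scatter) is therefore small and may not clear the scatter.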

Compound 4, half-maximal inhibitory concentration: 5070 nM
Compound 4: the middle estimate sits 1.8-fold (0.25 log units) above what was measured; low and high end bracket the measured number.
By their numbers in this assay, from the lowest: compounds 4, 2 and 1 (each within the scatter of the next); then compound 3.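

In this assay, the change from 4-methylphenyl to 2-(trifluoromethyl)phenyl gives a 3.0-fold lower number from compound 3 to compound 4 (0.48 log units; beyond the scatter), which shows that this aromatic carbon on the five-membered ring accepts a group with more heavy atoms and a substituent in a new place on the phenyl ring without a rise in the number. Against the 4-fluorophenyl group, the same group gives a 1.3-fold lower number from compound 2 to compound 4 (0.10 log units; within the scatter), so the two cannot be told apart, and among the three aryl groups shown, only the 4-methylphenyl of compound 3 stands apart. Nothing measured here accounts for these shifts.

On these data alone, whether the lower number belongs to the trifluoromethyl group itself or to where it sits on the phenyl ring stays open, since this change alters both at once. Also open, as far as these compounds go, is how an amine or a carboxylic acid on that phenyl ring would read in this assay.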